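The compounds below may be only part of what the source reports. "The series", "measured", "known", "first", "only" and "open" are said of these compounds alone.

Going by the values given here, in a functional assay on KB cells (Homo sapiens) for antiproliferative activity, read by MTT assay (a higher number here means a weaker inhibitor, a lower number a stronger inhibitor), compound 1 `Fc1ccc(N2CCN(c3nc(-n4ccc5ccccc54)c4ccccc4n3)CC2)cc1` gives 50 ug/mL and stands level with the other two compounds measured so far. Compound 2 `COc1cc(OC)c(-c2nc(N3CCN(C)CC3)nc3ccccc23)c(OC)c1` gives 50 ug/mL there and compound 3 `Cn1cc(-c2nc(N3CCNCC3)nc3ccccc23)c2ccccc21` gives 50 ug/mL there too. Among the compounds with values here, these three compounds differ from one another in more than one place, so the data hold no single-place step that could show how large a change of this kind might be. Compound 4 `c1ccc(N2CCN(c3nc(-n4ccc5ccccc54)c4ccccc4n3)CC2)nc1` has not yet been measured. It carries pyridin-2-yl in place of 4-fluorophenyl on an amine nitrogen in a ring. With compound 1 at 50 ug/mL as the closest reference, and with all three measured compounds level, no step beyond the scatter is expected in this assay for this change, in either direction. The step of no change at the digits printed from compound 1 to compound 4 (within the scatter) is estimated to stay within the scatter. For compound 4 the expected value is 50 ug/mL (estimated range 25 ug/mL to 100 ug/mL).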

Compound 4, half-maximal inhibitory concentration: 50 ug/mL
The estimate for compound 4 equals the measured number at the digits printed, and the stated range covers the measured number.
By their numbers in this assay, from the lowest: compounds 1, 2, 3 and 4 (each within the scatter of the next).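

In this assay, going by these compounds alone, the exchange of 4-fluorophenyl for pyridin-2-yl gives the first single-place step in these data, and it reads no change at the digits printed from compound 1 to compound 4 (within the scatter). At this place, on an amine nitrogen in a ring, an aromatic ring of carbon only can therefore give way to one with a ring nitrogen and one hydrogen-bond acceptor without a step beyond the scatter. No measured evidence bears on this result.

The compounds shown leave open whether a group of another kind on the same nitrogen, such as benzyl or acetyl, would give a step beyond the scatter. They also leave open whether a carboxylic acid or an amine on the pyridin-2-yl ring would move the reading, as a single step from compound 4.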